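The source may report more compounds than this note shows. Statements on the series, on what has been measured and on what is new or still open speak of the compounds shown alone.

Compound 1, with structure `COc1ccccc1Oc1ccc2c(NCCCNCc3ccco3)ccnc2c1`, is the standout among the two compounds measured here. In an ADME assay for permeability, using PAMPA, with a stated time of 30 min, at pH 7.4 (a lower number here means that the compound crosses the layer more slowly, a higher number that the compound crosses the layer faster), compound 1 gives 317 10^-6 cm/s, the highest of the two numbers. The other measured compound, compound 2 with structure `COc1ccc(F)cc1CNCCCNc1ccnc2cc(Cc3cc(C)cc(C)c3)ccc12`, gives 23 10^-6 cm/s in this assay, a far lower number that lies beyond the usual scatter of such measurements.

The next compound to be considered is compound 3, with structure `c1coc(CNCCCNc2ccnc3cc(-c4cccc5ccccc45)ccc23)c1`, which has not yet been measured in this assay. It differs from compound 1 in a single place: naphthalen-1-yl in place of 2-methoxyphenoxy on an aromatic carbon. What leaves carries two hydrogen-bond acceptors; what enters carries none, and brings one more six-membered aromatic ring of carbon only.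

Among the measured compounds shown here, no step between two measured compounds that differ in just one place is available, so there is no direct guide for what this change will do in this assay. The expectation is that the step of a 1.3-fold lower number from compound 1 to compound 3 (0.10 log units; within the scatter) stays small, no larger than the scatter. Compound 3 is therefore estimated to give 250 10^-6 cm/s in this assay, within a range from 100 10^-6 cm/s to 500 10^-6 cm/s.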

Compound 3, apparent permeability: 237 10^-6 cm/s
Beside the measured number, compound 3's estimate is 1.1-fold (0.02 log units) above it; low and high end bracket the measured number.
By their numbers in this assay, from the lowest: compound 2; then compounds 3 and 1 (each within the scatter of the next).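

In this assay, among the compounds shown here, replacing 2-methoxyphenoxy with naphthalen-1-yl on this aromatic carbon gives a 1.3-fold lower number from compound 1 to compound 3 (0.13 log units; within the scatter), the first direct reading of a change at this position. The two compounds cannot be told apart in this read-out, even though the group that leaves carries two hydrogen-bond acceptors and one six-membered aromatic ring of carbon only, while the group that enters carries no hydrogen-bond acceptors and two such rings. Nothing given here offers a reason for such a small step.

For the compounds shown here, this is still a single pair, so it shows only that these two groups give numbers within the scatter of each other, not that any group placed on this carbon would do the same. Going by these compounds, whether a much smaller or charged group, such as a fluorine atom or a carboxylic acid, would also leave the number within the scatter stays open, as does the effect of a change at this position on a compound with a different side chain.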